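The compounds below may be only part of what the source reports. "The series", "measured", "known", "first", "only" and "open" are said of these compounds alone.

Measured compounds:
- compound 1 `CN(Cc1ccccc1)c1cc(C(=O)Nc2ccccc2)ncn1`: 314000 nM in an ADME assay on Vero cells (Chlorocebus sabaeus) for cytotoxicity, read by MTT assay; on this read-out lower numbers stand for stronger inhibition and higher numbers for weaker inhibition
- compound 2 `O=C(Nc1ccccc1)c1cc(NCc2ccccc2)ncn1`: "not determined" (no result reported) in this assay
- compound 3 `CN(c1ccccc1)c1cc(C(=O)Nc2ccccc2)ncn1`: "not determined" (no result reported) in this assay

Going by the values given here, compound 1 is the only member of the series with a number in this assay; compound 2 and compound 3 carry no result there, so no step between measured compounds can be drawn and compound 1 stands alone as the reference point. Its value in this assay is high, which on this read-out means weak inhibition of the Vero cells.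

The next compound, compound 4 `CN(Cc1ccc(C(F)(F)F)cc1)c1cc(C(=O)Nc2ccccc2)ncn1`, differs from compound 1 by a single change: trifluoromethyl in place of hydrogen on an aromatic carbon. Nothing in the measured set speaks to what a trifluoromethyl group does in this assay, so the expectation rests on the weak starting point of compound 1 alone. The step from compound 1 to compound 4 in this assay is expected to be small, a 1.6-fold lower number from compound 1 to compound 4 (0.20 log units; within the scatter), and it is expected to stay within the usual scatter or only just beyond it, leaning toward somewhat lower numbers.

Compound 4 is therefore estimated at 200000 nM in this assay, with a range from 60000 nM to 600000 nM.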

Compound 4, half-maximal inhibitory concentration: 258000 nM
Beside the measured number, compound 4's estimate is 1.3-fold (0.11 log units) below it, and the stated range covers the measured number.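

In this assay, trifluoromethyl in place of hydrogen on an aromatic carbon, para to a large group, gives a 1.2-fold lower number from compound 1 to compound 4 (0.09 log units; within the scatter). Compound 1 alone could not show whether a substituent at this position moves the read-out; this single change does not move it beyond the scatter, and the pair stays at the weak end of this assay. No data here bear on the reason for this result.

Going by these compounds, whether a carboxylic acid, an amine or a longer chain at the same position would also leave the number in place remains open, as does the effect of trifluoromethyl elsewhere on the same ring. On these data alone, the steps to compound 2 and compound 3 cannot be read, so the contribution of the nitrogen substituents of compound 1 also remains open.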